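Chain Length Change in Two Benzoxazole Cytotoxicity Series

The compounds below may be only part of what the source reports. "The series", "measured", "known", "first", "only" and "open" are said of these compounds alone.

Of the compounds shown here, three that share a common skeleton have been tested in a functional assay on MCF7 cells (Homo sapiens) for cytotoxicity, read by MTT assay, with a stated time of 24 h; on this read-out higher numbers stand for weaker inhibition and lower numbers for stronger inhibition. Compound 1 `Cc1ccc2oc(-c3ccc(NC(=O)CN4CCN(CCN(C)C)CC4)cc3)nc2c1` gives 23700 nM in this assay. Compound 3 `Cc1ccc2oc(-c3ccc(NC(=O)CN4CCN(CCCN(C)C)CC4)cc3)nc2c1` gives 19100 nM in this assay. The two are related by a single change, ((dimethylamino)methyl in place of dimethylamino on a saturated chain carbon, two bonds along the chain from an amine nitrogen in a ring), and that change gave a 1.2-fold lower number from compound 1 to compound 3 (0.09 log units; within the scatter). Compound 2 `Cc1cc(-c2nc3cc(Cl)ccc3o2)ccc1NC(=O)CN1CCN(CCN(C)C)CC1` gives 39300 nM in this assay; it carries the same side chain as compound 1 on a different core, and the difference between the two cores is not broken down here.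

Compound 4 `Cc1cc(-c2nc3cc(Cl)ccc3o2)ccc1NC(=O)CN1CCN(CCCN(C)C)CC1` is not yet measured in this assay. It is to compound 2 what compound 3 is to compound 1: the change is (dimethylamino)methyl in place of dimethylamino on a saturated chain carbon, two bonds along the chain from an amine nitrogen in a ring, at the same place in the chain. For the measured compounds named here, since the only measured example of this change, between compound 1 and compound 3, stayed within the scatter, the expectation is that the step from compound 2 to compound 4 will be of similar size, estimated as a 1.2-fold lower number from compound 2 to compound 4 (0.09 log units; within the scatter). That rests on one pair only, so the range around the expectation is kept wide. On this basis compound 4 is expected to give about 32000 nM in this assay, with a likely span from 14000 nM to 75000 nM.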

Compound 4, half-maximal inhibitory concentration: 63400 nM
For compound 4 the middle estimate is 2.0-fold (0.30 log units) below the measured one; measured number inside the range.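

Replacing 2-(dimethylamino)ethyl with 3-(dimethylamino)propyl on the core of compound 2 gives a 1.6-fold higher number from compound 2 to compound 4 (0.21 log units; within the scatter) in this assay. Set beside the same change on the core of compound 1, the two results cannot be told apart: the same change on two cores in this assay, a 1.2-fold lower number (0.09 log units; within the scatter) from compound 1 to compound 3 and a 1.6-fold higher number (0.21 log units; within the scatter) from compound 2 to compound 4, 2.0-fold (0.30 log units) apart, within the scatter of two such steps

The two steps point in opposite directions on paper, but neither is larger than the ordinary spread of repeat measurements, so this should not be read as a reversal between the cores. The pairs therefore give no sign that the change behaves differently on one core than on the other, but they do not prove that it carries over exactly, or that it has no effect at all, as two pairs are few and a small real effect could hide in that spread.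

The compounds shown leave open whether a longer chain, such as 4-(dimethylamino)butyl, or a different end group, such as a primary amine or a morpholine ring, would produce a step beyond the scatter. Also open, on these data alone, is how each single difference between the two cores acts on its own, as these cores differ in more than one place.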